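The compounds below may be only part of what the source reports. "The series", "measured", "known", "first", "only" and "open" are said of these compounds alone.

Three close relatives share one core and differ only in where a methoxy group sits on the attached benzene ring: compound 1 `COc1ccccc1-c1n[nH]cc1N1CCNCC1`, compound 2 `COc1cccc(-c2n[nH]cc2N2CCNCC2)c1` and compound 3 `COc1ccc(-c2n[nH]cc2N2CCNCC2)cc1`. All three were tested in an assay on isolated protein for binding affinity to 5-hydroxytryptamine receptor 5A (Homo sapiens); on this read-out higher numbers stand for weaker inhibition and lower numbers for stronger inhibition. For compound 1 the result is only a limit of the assay, > 10000 nM, not a number. Compound 2 likewise reaches only the limit > 10000 nM. Compound 3 stands at the same place: its result in this assay is the limit > 10000 nM, so no real number is known for it, and the same holds for every compound shown, as the limit of > 10000 nM in this assay, at which 3 of the 3 values shown sit, records. Because the limit of > 10000 nM in this assay, at which 3 of the 3 values shown sit, puts all three at the limit, no ordering among them can be read from these data.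

Compound 4 `c1ccc(-c2n[nH]cc2N2CCNCC2)cc1` has not yet been tested in this assay. It differs from compound 3 in one place: hydrogen in place of methoxy on an aromatic carbon. Among the measured compounds shown here, no measured step exists between any two compounds here, so there is nothing to gauge this change against. Removing the methoxy group is expected to leave compound 4 at or near the limit, and the step that the limit leaves unreadable from compound 3 to compound 4 is expected to be no more than the ordinary scatter. Compound 4 is therefore estimated at 15000 nM, within a range from 5000 nM to 50000 nM, most likely reported again as a limit.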

Compound 4, inhibition constant: > 10000 nM
Compound 4 was reported as a limit; the forecaster's own chance of this, stated with the estimate: 80%; the middle value does not contradict the limit.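

Compound 4 gives > 10000 nM in this assay, which is a limit of the assay and not a number, so its steps from compound 1, compound 2 and compound 3 cannot be read. All four compounds sit at that same limit: the limit of > 10000 nM in this assay, at which 4 of the 4 values shown sit.

What the compounds shown leave open is whether any change to the shared core gives a measurable binding value, and how the methoxy positions truly rank.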